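The source may report more compounds than this note shows. Statements on the series, on what has been measured and on what is new or still open speak of the compounds shown alone.

Measured compounds:
Compound 1 `C=CC1=C(C(=O)NC(C)(C)C)C(c2ccc(OC)cc2)OC1` — in a functional assay on QGY7701 cells (Homo sapiens) for cytotoxicity, read by MTT assay, with a stated time of 24 h (on this read-out lower numbers stand for stronger inhibition and higher numbers for weaker inhibition), compound 1 reports > 100000 nM, which is a limit of the assay and not a number.
Compound 2 `C=CC1=C(C(=O)NCc2ccccc2F)C(c2ccc(F)cc2)OC1` — in this assay compound 2 gives 51400 nM.
Compound 3 `C=CC1=C(C(=O)NC2CCCCC2)C(c2ccc(F)cc2)OC1` — in this assay compound 3 gives 40500 nM.

Compound 3 has the lowest of the two numbers; compound 2 sits within the scatter of it, so no order between the two is claimed. For the measured compounds named here, the only measured step, a 1.3-fold lower number from compound 2 to compound 3 (0.10 log units; within the scatter), shows a change on the amide-type nitrogen that left the read-out essentially unchanged.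

Compound 4 `C=CC1=C(C(=O)NC(C)(C)C)C(c2ccc(F)cc2)OC1` differs from compound 3 by tert-butyl in place of cyclohexyl on an amide-type nitrogen. Going by the values given here, no measured step covers this exchange directly. Compound 1 carries the same tert-butyl group and shows only a limit, (the limit of > 100000 nM in this assay, at which 1 of the 3 values shown sits), but compound 1 also differs from compound 4 elsewhere, so its value is at best a loose pointer. Against that, the one measured amide change was within the scatter.

The step of a 2.0-fold higher number from compound 3 to compound 4 (0.30 log units; within the scatter) is therefore expected to be a modest loss, with a real chance of a limit. Compound 4 is estimated at 80000 nM, in the range 35000 nM to 200000 nM.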

Compound 4, half-maximal inhibitory concentration: > 100000 nM
Compound 4: a limit, no number; the forecaster's own chance of this, stated with the estimate: 40%; at least 1.2-fold (0.09 log units) between middle value and limit.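

In this assay compound 4 reads as a limit and not a number: the limit of > 100000 nM in this assay, at which 2 of the 4 values shown sit.

For the compounds shown here, the amide-type nitrogen now shows a change that can be read, since an at least 2.4-fold higher number from compound 3 to compound 4 (0.39 log units; beyond the scatter), whereas the only earlier step on this nitrogen, a 1.3-fold lower number from compound 2 to compound 3 (0.10 log units; within the scatter), showed none. The exchange of 2-fluorobenzyl for tert-butyl gives an at least 1.9-fold higher number from compound 2 to compound 4 (0.28 log units; that floor lies within the scatter), so no order is claimed for that pair, and the clear separation holds only for cyclohexyl against tert-butyl.

From the compounds shown here alone, the step between compound 1 and compound 4 cannot be read, so fluoro in place of methoxy on an aromatic carbon remains open. Also open, going by these compounds, is whether a cyclopentyl group, or a longer chain ending in an amine, on the same nitrogen would give a number clearly lower than that of compound 3.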